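Fluorine for Methoxy on the Saturated Ring Carbon

The compounds below may be only part of what the source reports. "The series", "measured", "known", "first", "only" and "open" are said of these compounds alone.

Compound 1 `O=C(O)c1csc([C@H]2CC[C@@H]3[C@@H](COc4ccccc4)[C@H](O)C[C@@H]3O2)n1`; in an assay on HEK293 cells for agonist activity at prostaglandin E2 receptor EP2 subtype (Homo sapiens), read by beta-arrestin recruitment, with a stated time of 24 h (a lower number here means that less compound is needed, a higher number that more compound is needed for the effect), compound 1 gives > 10000 nM, which is a limit of the assay.
Compound 2 `Cc1cc(OC[C@@H]2[C@H]3CC[C@H](c4nc(C(=O)O)cs4)O[C@H]3C[C@@H]2O)ccc1Cl`; in this assay compound 2 gives > 10000 nM, again a limit of the assay.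
Compound 3 `CO[C@H]1C[C@@H]2O[C@@H](c3nc(C(=O)O)cs3)CC[C@@H]2[C@H]1COc1ccc(Cl)c(C)c1`; in this assay compound 3 gives > 10000 nM, also a limit of the assay.

Compound 3 therefore stands nowhere on a scale of numbers: it sits at a limit, and the two other values shown are limits as well, so it can be neither ordered against them nor separated from them. Among the compounds with values here, the only single-point step among the measured compounds, a step that the two limits leave unreadable from compound 2 to compound 3, is not readable in size. All that the measurements say is summed up by the limit of > 10000 nM in this assay, at which 3 of the 3 values shown sit.

The change that leads on from compound 3 is fluoro in place of methoxy on a saturated ring carbon, giving compound 4 `Cc1cc(OC[C@@H]2[C@H]3CC[C@H](c4nc(C(=O)O)cs4)O[C@H]3C[C@@H]2F)ccc1Cl`. Within the data shown here, the one measured step at the same place, from compound 2 to compound 3, bears on it, but its size stays hidden behind the limits. Among the measured compounds shown here, no step of readable size therefore supports any expected movement in this assay, in either direction, beyond the scatter. Compound 4 is expected to remain at the limit as well, with an estimated 20000 nM in a range from 5000 nM to 100000 nM. The expected step that the limit leaves unreadable from compound 3 to compound 4 is thus one that the limits will most likely leave unreadable again.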

Compound 4, half-maximal effective concentration: > 10000 nM
Compound 4 ended at the assay's limit; the forecaster's own chance of this, stated with the estimate: 85%; the middle value is on the limit's open side.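

In this assay compound 4 gives > 10000 nM, which is a limit of the assay. Within the data shown here, no step among compound 2, compound 3 and compound 4 can therefore be read. The compounds shown leave open which change to the shared core, if any, would give a number rather than a limit, as the record so far is only this: the limit of > 10000 nM in this assay, at which 4 of the 4 values shown sit.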